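Swapping a methyl for an azido on the aryl ring

The source may hold more compounds than are shown below. What is called first, only, known or untested is meant among the compounds shown, and "the series" means these compounds.

Compound 1 has the structure `Cc1cccc(C2=NCCNc3c2c(C)nn3C)c1`. Among the compounds with values here, in a functional assay on the whole organism for positive allosteric modulation, with Rattus norvegicus as the target (on this read-out lower numbers stand for an effect already at smaller amounts and higher numbers for an effect only at larger amounts of compound), compound 1 gives 2.5 mg/kg, the only plain number among the values shown. Compound 2, `Cc1cccc(C2=NCCN(CCCN(C)C)c3c2c(C)nn3C)c1`, carries a 3-(dimethylamino)propyl in place of hydrogen on a nitrogen on an aromatic ring in a ring; in this assay compound 2 reaches only the limit > 10 mg/kg, which is a bound of the assay rather than a number. That change gives an at least 4.0-fold higher number from compound 1 to compound 2 (0.60 log units; beyond the scatter), resting on (the limit of > 10 mg/kg in this assay, at which 1 of the 2 values shown sits).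

Compound 3, `Cc1nn(C)c2c1C(c1cccc(N=[N+]=[N-])c1)=NCCN2`, differs from compound 1 in another place: azido in place of methyl on an aromatic carbon. Within the data shown here, the one measured step concerns the ring nitrogen, not this aromatic carbon, so no measured step bears on the change, and a step no larger than the usual scatter is expected, in either direction. The estimated step is a 1.2-fold higher number from compound 1 to compound 3 (0.08 log units; within the scatter). For compound 3 in this assay a value of 3 mg/kg is expected, between 1.2 mg/kg and 8 mg/kg.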

Compound 3, minimum effective dose: 2.5 mg/kg
Compound 3: the middle estimate sits 1.2-fold (0.08 log units) above what was measured; low and high end bracket the measured number.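

In this assay, replacing methyl with azido on this aromatic carbon gives no change at the digits printed from compound 1 to compound 3 (within the scatter), so the earlier step at the ring nitrogen had said nothing about this site. Here, on a six-membered aromatic ring of carbon only, a group of 3 heavy atoms, all nitrogen, can stand in place of a single carbon without moving the minimum effective dose beyond the usual scatter. Nothing shown here explains why the read-out holds at this position.

This single swap leaves open how much wider the range of tolerated groups at this aromatic carbon is. A carboxylic acid, an amine or a longer chain such as butyl could behave like azido or could shift the dose, and the compounds shown cannot tell which.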